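The compounds below may be only part of what the source reports. "The series", "measured", "known", "first", "only" and "open" are said of these compounds alone.

Measured compounds in an ADME assay on MDCK cells (Canis lupus familiaris) for cytotoxicity, read by MTT assay, with a stated time of 24 h; a higher number here means that more compound is tolerated, a lower number that less compound is tolerated:
compound 1 `Cc1cc(CNS(=O)(=O)c2ccc(Cl)cc2)c(C)o1` — 55700 nM
compound 2 `Cc1cc(CNS(=O)(=O)c2ccc(Br)cc2)c(C)o1` — 29600 nM
compound 3 `O=S(=O)(NCc1cc2ccccc2s1)c1ccc(Cl)cc1` — "not determined" (no result reported)

Compound 1 and compound 2 share a core and differ by one change, (bromo in place of chloro on an aromatic carbon). The measured step is a 1.9-fold lower number from compound 1 to compound 2 (0.27 log units; within the scatter).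

Compound 3 carries a different core; how the two cores differ is not broken down here. Compound 4 `O=S(=O)(NCc1cc2ccccc2s1)c1ccc(Br)cc1` is related to compound 3 by bromo in place of chloro on an aromatic carbon, the same change as that made from compound 1 to compound 2, at the same kind of place.

With no result for compound 3 in this assay, the expectation for compound 4 rests only on compound 1 and compound 2 and on the size of their step of a 1.9-fold lower number from compound 1 to compound 2 (0.27 log units; within the scatter), and is therefore uncertain. For compound 4 the expected value in this assay is estimated at 30000 nM, likely between 8000 nM and 110000 nM.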

Compound 4, half-maximal cytotoxic concentration: > 174000 nM
Compound 4 ended at the assay's limit; the forecaster's own chance of this, stated with the estimate: 20%; middle value at least 5.8-fold (0.76 log units) from the limit.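

Within the data shown here, no step from compound 3 to compound 4 can be read: in this assay compound 4 gives > 174000 nM, a limit of the assay and not a number. Going by these compounds, whether bromo in place of chloro acts on the core of compound 3 as it does on the core of compound 1 stays open.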